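A few compounds are considered here, and "the series" means these few. Any claim that something is new, unique, unknown or untested is made for them only; others in the source may bear on it.

Three compounds built on the same core differ only in the aryl group attached to the amide-type nitrogen of the side chain. Compound 1 `CCN(CC)CCCNc1nc(-c2ccc(NC(=O)Nc3ccccc3Cl)cc2)nc2c(Cl)c(Cl)sc12` gives 410 nM in a functional assay on HT-29 cells (Homo sapiens) for cytotoxicity, read by MTT assay, with a stated time of 72 h; a lower number here means a stronger inhibitor, a higher number a weaker inhibitor. Compound 2 `CCN(CC)CCCNc1nc(-c2ccc(NC(=O)Nc3ccc(Cl)cc3Cl)cc2)nc2c(Cl)c(Cl)sc12` gives 1230 nM, and compound 3 `CCN(CC)CCCNc1nc(-c2ccc(NC(=O)Nc3ccc(C)cc3)cc2)nc2c(Cl)c(Cl)sc12` gives 890 nM. Compound 2 holds the highest of the three numbers, yet only part of that stands firm: the step of a 3.0-fold higher number from compound 1 to compound 2 (0.48 log units; beyond the scatter) lies beyond the scatter, the step of a 2.2-fold higher number from compound 1 to compound 3 (0.34 log units; beyond the scatter) also lies beyond it, but the step of a 1.4-fold lower number from compound 2 to compound 3 (0.14 log units; within the scatter) lies within the scatter, so compound 2 and compound 3 cannot be told apart.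

Compound 4 `CCN(CC)CCNc1nc(-c2ccc(NC(=O)Nc3ccc(Cl)cc3Cl)cc2)nc2c(Cl)c(Cl)sc12` keeps the aryl group of compound 2 and alters the other end of the molecule: diethylamino in place of (diethylamino)methyl on a saturated chain carbon, two bonds along the chain from a nitrogen on an aromatic ring. The chain that carries the diethylamino group thus becomes one carbon shorter. Going by the values given here, none of the measured steps touches this part of the structure; all three concern the aryl group on the amide-type nitrogen. Among the compounds with values here, no measured step therefore guides the expectation, and the plain assumption is a step of no clear direction, a 1.0-fold lower number from compound 2 to compound 4 (0.01 log units; within the scatter), within a wide range. Compound 4 is accordingly estimated at 1200 nM in this assay, with a range from 450 nM to 3200 nM.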

Compound 4, half-maximal inhibitory concentration: 1140 nM
For compound 4 the middle estimate is 1.1-fold (0.02 log units) above the measured one; measured number inside the range.
By their numbers in this assay, from the lowest: compound 1; then compounds 3, 4 and 2 (each within the scatter of the next).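

Shortening the side chain from 3-(diethylamino)propyl to 2-(diethylamino)ethyl on the nitrogen attached to the aromatic ring gives, in this assay, a 1.1-fold lower number from compound 2 to compound 4 (0.03 log units; within the scatter), so compound 2 and compound 4 cannot be told apart. Going by these compounds alone, this is the first measured change at this end of the molecule, and with the 2,4-dichlorophenyl group in place, removing one carbon from the chain leaves the cytotoxicity reading unchanged within the scatter. Nothing measured here offers an explanation for this result.

Still open, as far as these compounds go, is whether a longer chain, such as 4-(diethylamino)butyl, or another amine, such as morpholine or dimethylamino, in place of diethylamino, would shift the number. From the compounds shown here alone, it is also open whether the same shortening would leave the number unchanged with the 2-chlorophenyl group of compound 1.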